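From 4-carboxy-1-methylcyclohexyl to 4-carbamoylcyclohexyl: stability notes

A few compounds are considered here, and "the series" means these few. Any claim that something is new, unique, unknown or untested is made for them only; others in the source may bear on it.

For the measured compounds named here, in an ADME assay on microsomes from liver (Homo sapiens) for metabolic stability, with a stated time of 10 min (on this read-out higher numbers stand for a more stable compound and lower numbers for a less stable compound), compound 2 (`C[C@]1(C(=O)N2CC[C@](c3ccc(C(F)(C(F)(F)F)C(F)(F)F)cc3)(S(=O)(=O)c3ccc(F)cc3)C2)CC[C@@H](C(=O)O)CC1`) gives 85% and is the only compound with a single number. Compound 3 (`O=C1NC(=O)C2(CCC(C(=O)N3CC[C@](c4ccc(C(F)(C(F)(F)F)C(F)(F)F)cc4)(S(=O)(=O)c4ccc(F)cc4)C3)CC2)N1`) gives 84%; 93% (2 entries) (the several entries of compound 3 in this assay, 84%; 93% (2 entries)), which lies within the scatter of compound 2. For compound 1 (`O=C(O)[C@H]1CC[C@](F)(C(=O)N2CC[C@](c3ccc(C(F)(C(F)(F)F)C(F)(F)F)cc3)(S(=O)(=O)c3ccc(F)cc3)C2)CC1`) the record reads "not determined" (no result reported) and offers no comparison.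

Compound 4 (`NC(=O)[C@H]1CC[C@H](C(=O)N2CC[C@](c3ccc(C(F)(C(F)(F)F)C(F)(F)F)cc3)(S(=O)(=O)c3ccc(F)cc3)C2)CC1`) carries 4-carbamoylcyclohexyl in place of 4-carboxy-1-methylcyclohexyl on a carbonyl carbon. Going by the values given here, no measured pair shows the effect of this change in this assay, so no shift beyond the scatter is expected, in either direction. The estimated step is small (a number 2 percentage points lower from compound 2 to compound 4 (within the scatter)). For compound 4 the expected value is 83% with an estimated range of 68% to 95%.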

Compound 4, percent of the compound remaining: 100%
Compound 4: middle estimate off by 17 percentage points, on the low side, outside the stated range (above it).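

For the compounds shown here, this is the first single-place change read at this position, on a carbonyl carbon whose other neighbours are an amide-type nitrogen in a ring. In this assay it gives a number 15 percentage points higher from compound 2 to compound 4 (beyond the scatter), so the group here can move this read-out, and 4-carbamoylcyclohexyl is tolerated. Repeat entries of one compound also spread, so the size of the step stays approximate: the several entries of compound 3 in this assay, 84%; 93% (2 entries)

The change replaces the carboxylic acid with a carbamoyl group and removes the 1-methyl group together, so the compounds shown do not separate these two parts. Neither 4-carboxycyclohexyl nor 4-carbamoyl-1-methylcyclohexyl is among them.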